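This account rests on a few compounds, and the source may have more. Where it says the series, first, only, none or still open, it means among the compounds named here.

In a functional assay on MCF7 cells (Homo sapiens) for antiproliferative activity, read by colorimetric assay and MTT assay, with a stated time of 48 h (a lower number here means a stronger inhibitor, a higher number a weaker inhibitor), compound 1 `Cc1ccc(S(=O)(=O)NC(=O)c2cccnc2)cc1` gives 15500 nM, compound 2 `O=C(NS(=O)(=O)c1ccc(Cl)cc1)c1ccncc1` gives 10100 nM, and compound 3 `O=C(NS(=O)(=O)c1ccc(Br)cc1)c1ccncc1` gives 8700 nM. These three values lie within the scatter of one another, so compound 3 cannot be separated from either of the other two in this assay.

Compound 4 `Cc1ccc(S(=O)(=O)NC(=O)c2ccncc2)cc1` has methyl in place of bromo on an aromatic carbon. The closest measured step is the exchange of chloro for bromo on an aromatic carbon, a 1.2-fold lower number from compound 2 to compound 3 (0.06 log units; within the scatter), which stays within the scatter. It exchanges one halogen for another, so it is only an indirect guide to a methyl group. Compound 1 also carries the methyl group and gives 15500 nM, but it differs from compound 4 elsewhere in the structure. Neither comparison suggests a clear shift in either direction, so no change beyond the scatter is expected. The estimated change is a 1.3-fold higher number from compound 3 to compound 4 (0.10 log units; within the scatter). For compound 4, the estimated value is 11000 nM, with an expected range of 6000 nM to 20000 nM.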

Compound 4, half-maximal inhibitory concentration: 14100 nM
Compound 4: middle estimate off by 1.3-fold (0.11 log units), on the low side; the range from low to high includes it.
By their numbers in this assay, from the lowest: compounds 3, 2, 4 and 1 (each within the scatter of the next).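

In this assay, methyl on the aromatic carbon para to a large group reads no differently from the halogens: in place of bromo it gives a 1.6-fold higher number from compound 3 to compound 4 (0.21 log units; within the scatter) and in place of chloro it gives a 1.4-fold higher number from compound 2 to compound 4 (0.14 log units; within the scatter). Going by these compounds alone, with the methyl group held constant, pyridin-4-yl in place of pyridin-3-yl on the carbonyl carbon gives a 1.1-fold lower number from compound 1 to compound 4 (0.04 log units; within the scatter) and is the first reading of that change, which also stays within the scatter. Neither the exchange among methyl, chloro and bromo at this position nor the exchange of the pyridinyl groups therefore separates any of these compounds.

As far as these compounds go, whether an amine, a carboxylic acid or a longer chain at this position would give a value beyond the scatter remains open. No available evidence bears on these results.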